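Urea tail variation on the acylsulfonamide series: tert-butyl to methyl

The compounds below may be only part of what the source reports. "The series", "measured", "known", "first", "only" and "open" are said of these compounds alone.

Measured so far in an ADME assay on microsomes from liver (Rattus norvegicus) for metabolic stability, with a stated time of 10 min; a higher number here means that more of the compound is left, a lower number that less of the compound is left:
- compound 1 `Cc1ccccc1S(=O)(=O)NC(=O)c1ccc(Nc2nc(NC3(c4ccc(Cl)cc4)CC3)nc(OCC(F)(F)F)n2)cc1`: 100%
- compound 2 `CC(C)(C)NC(=O)NCCS(=O)(=O)NC(=O)c1ccc(Nc2nc(NC3(c4ccc(Cl)cc4)CC3)nc(OCC(F)(F)F)n2)cc1`: 93%
- compound 3 `CCCCCNc1nc(Nc2ccc([N+](=O)[O-])cc2)nc(OCC(F)(F)F)n1`: 35%

Compound 2 and compound 1 sit within the scatter of each other; compound 3, which carries a pentylamino group and a nitro group instead, shows a value far lower than compound 2. Within the data shown here, the only single-point step seen so far is a number 7 percentage points lower from compound 1 to compound 2 (within the scatter), a swap of the whole sulfonyl substituent that left the read-out essentially unchanged.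

Compound 4 `CNC(=O)NCCS(=O)(=O)NC(=O)c1ccc(Nc2nc(NC3(c4ccc(Cl)cc4)CC3)nc(OCC(F)(F)F)n2)cc1` is next. (methyl in place of tert-butyl on an amide-type nitrogen). Among the measured compounds shown here, no measured step touches this urea nitrogen, so the expectation rests on compound 2 and on the flat outcome of a number 7 percentage points lower from compound 1 to compound 2 (within the scatter). A step of a number 5 percentage points lower from compound 2 to compound 4 (within the scatter) is expected, within the scatter. Compound 4 is estimated at 88%, with a range from 70% to 100%.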

Compound 4, percent of the compound remaining: 100%
Estimate against measurement, compound 4: 12 percentage points below, and the stated range covers the measured number.
By their numbers in this assay, from the lowest: compound 3; then compounds 2, 1 and 4 (each within the scatter of the next).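

In this assay, the urea nitrogen of this series gives no readable difference when methyl replaces tert-butyl (a number 7 percentage points higher from compound 2 to compound 4 (within the scatter)). The 2-((methylcarbamoyl)amino)ethyl group on the sulfonyl sulfur also stands level with 2-methylphenyl (no change at the digits printed from compound 1 to compound 4 (within the scatter)), so both urea tails remain within the scatter of the aryl sulfonyl compound. No supporting data bear on why this position stays flat.

Still open, from the compounds shown here alone, is whether a longer chain, a cyclopropyl group or a carboxylic acid on this urea nitrogen would hold the read-out. The compounds shown also leave untested whether the flat outcome carries over to a shared core without the 1-(4-chlorophenyl)cyclopropyl amine.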